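Amide aryl replacement on the shared core: compound 4

The source may hold more compounds than are shown below. What is called first, only, known or untested is meant among the compounds shown, and "the series" means these compounds.

Measured compounds:
Compound 1, `O=C(Nc1ccc(Cl)c(-c2nnc3c(Cl)cccn23)c1)c1ccc(C(F)(F)F)cc1Cl`: in a functional assay on T47D cells (Homo sapiens) for antiproliferative activity, read by MTT assay, with a stated time of 72 h (on this read-out higher numbers stand for weaker inhibition and lower numbers for stronger inhibition), compound 1 gives > 100000 nM, a limit of the assay.
Compound 2, `O=C(Nc1ccc(Cl)c(-c2nnc3c(Cl)cccn23)c1)c1cccnc1`: in this assay compound 2 gives > 100000 nM, again a limit of the assay.
Compound 3, `O=C(Nc1ccc(Cl)c(-c2nnc3c(Cl)cccn23)c1)c1ccc(C(F)(F)F)cc1F`: in this assay compound 3 gives 70800 nM.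

Compound 2 stands at the limit of the assay, and only compound 3 returns a number; overall, (the limit of > 100000 nM in this assay, at which 2 of the 3 values shown sit). For the measured compounds named here, the single measured step, an at least 1.4-fold lower number from compound 1 to compound 3 (0.14 log units; that floor lies within the scatter), lies within the scatter and concerns an exchange on an aromatic carbon, not the group on the carbonyl carbon.

Compound 4, `CS(=O)(=O)c1ccc(C(=O)Nc2ccc(Cl)c(-c3nnc4c(Cl)cccn34)c2)cc1`, differs from compound 2 in 4-(methylsulfonyl)phenyl in place of pyridin-3-yl on a carbonyl carbon. Going by the values given here, no measured step touches the group on the carbonyl carbon, so there is no precedent here for this exchange. Compound 1 and compound 3 carry other groups on that carbon and all three measured compounds sit at or just inside the limit, so no movement beyond the scatter is expected, and the step of a number no higher from compound 2 to compound 4 (the limit leaves the size open) is expected to be small. Compound 4 is therefore estimated at 100000 nM in this assay, with a range from 30000 nM to 300000 nM, most likely reported again as a limit.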

Compound 4, half-maximal inhibitory concentration: > 100000 nM
Compound 4: only a limit was reported; the forecaster's own chance of this, stated with the estimate: 70%; the middle value lies on the limit itself.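

No step can be read between compound 2 and compound 4, as both stand at a limit in this assay: the limit of > 100000 nM in this assay, at which 3 of the 4 values shown sit.

On these data alone, whether 4-(methylsulfonyl)phenyl in place of pyridin-3-yl on a carbonyl carbon changes antiproliferative activity at all, and in which direction, remains open.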